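The compounds below may be only part of what the source reports. "The series", "measured", "known", "first", "only" and "open" are said of these compounds alone.

Compound 1 `Cn1nc2c(=O)n(CC3(O)CCN(Cc4ccc(-c5ccco5)cc4Cl)CC3)cnc2c1-c1ccc(Cl)cc1` gives 143 nM in an assay on isolated protein for inhibition of ubiquitin carboxyl-terminal hydrolase 7 (Homo sapiens), with stated times of 30 min and 2 h; a higher number here means a weaker inhibitor, a lower number a stronger inhibitor.
Compound 2 `Cn1cc(-c2ccc(CN3CCC(O)(Cn4cnc5c(-c6ccc(CN)cc6)n(C)nc5c4=O)CC3)c(Cl)c2)cn1` gives 291 nM in this assay.

Going by the values given here, of the two numbers so far, compound 2 stands at the higher one; compound 1 gives the lower number, and the gap between the two lies beyond the usual scatter. Compound 3 `Cn1nc2c(=O)n(CC3(O)CCN(Cc4ccc(-c5ccsc5Cl)cc4Cl)CC3)cnc2c1-c1ccc(CN)cc1` is not yet measured. It differs from compound 2 in one place: 2-chlorothiophen-3-yl in place of 1-methyl-1H-pyrazol-4-yl on an aromatic carbon. Among the compounds with values here, no single-change step between measured compounds is available, so the expectation rests on the two values alone. A modest lowering of the number is expected, a step of a 1.5-fold lower number from compound 2 to compound 3 (0.16 log units; within the scatter) in this assay. Compound 3 is therefore estimated at 200 nM, with a range from 80 nM to 500 nM.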

Compound 3, half-maximal inhibitory concentration: 453 nM
The estimate for compound 3 lay 2.3-fold (0.36 log units) below the measured number; the range from low to high includes it.
By their numbers in this assay, from the lowest: compound 1; then compounds 2 and 3 (each within the scatter of the next).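

Going by these compounds alone, on an aromatic carbon para to a large group, 2-chlorothiophen-3-yl in place of 1-methyl-1H-pyrazol-4-yl gives a 1.6-fold higher number from compound 2 to compound 3 (0.19 log units; within the scatter) in this assay, the first single-change reading in this set. At this position, then, exchanging one five-membered aromatic ring for another with the same heavy-atom count leaves the two numbers within the scatter of each other. No measurement shown accounts for this result. The compounds shown leave open whether a six-membered ring such as phenyl or morpholine, or an open group such as an amine, at this position would move the number beyond the scatter.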